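Extending the aryl arm of an acyltransferase inhibitor

This account rests on a few compounds, and the source may have more. Where it says the series, first, only, none or still open, it means among the compounds named here.

Compound 1 `CCCCCCCCS(=O)(=O)Nc1ccc(-c2ccccc2Cl)cc1C(=O)O` — 14400 nM
Compound 2 `CCCCCCCCS(=O)(=O)Nc1ccc(-c2ccccc2OC)cc1C(=O)O` — 27600 nM
Compound 3 `CCCCCCCCS(=O)(=O)Nc1ccc(-c2ccccc2O)cc1C(=O)O` — 61700 nM

Of the compounds shown here, three sharing one core have been tested in an assay on mitochondria (strain BALB/c) for inhibition of glycerol-3-phosphate acyltransferase 1, mitochondrial (Mus musculus), read by scintillation counting, with a stated time of 10 min; a higher number here means a weaker inhibitor, a lower number a stronger inhibitor. Compound 3 gives the highest number of the three, so it is the weakest inhibitor here: the step of a 2.2-fold higher number from compound 2 to compound 3 (0.35 log units; beyond the scatter) and the step of a 4.3-fold higher number from compound 1 to compound 3 (0.63 log units; beyond the scatter) both lie beyond the scatter, while a 1.9-fold higher number from compound 1 to compound 2 (0.28 log units; within the scatter) does not.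

Compound 4 `CCCCCCCCS(=O)(=O)Nc1ccc(/C=C/c2ccc(OC)cc2)cc1C(=O)O` is not yet measured. Its change from compound 3 is 2-(4-methoxyphenyl)ethenyl in place of 2-hydroxyphenyl on an aromatic carbon. Among the measured compounds shown here, none of the measured steps swaps the whole ring for a longer arm, so they bear on this only in part. The closest is the reverse of a 2.2-fold higher number from compound 2 to compound 3 (0.35 log units; beyond the scatter), where a methyl on the oxygen in place of hydrogen gave a lower number, and the change to compound 4 likewise removes the hydrogen-bond donor. For the measured compounds named here, the added double bond and the different placement of the methoxy have no measured counterpart. The expectation is therefore a modest step down, a 4.1-fold lower number from compound 3 to compound 4 (0.61 log units; beyond the scatter), carrying real uncertainty. Compound 4 is estimated at 15000 nM in this assay, with a range from 4000 nM to 60000 nM.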

Compound 4, half-maximal inhibitory concentration: 37100 nM
Beside the measured number, compound 4's estimate is 2.5-fold (0.39 log units) below it; the measured number falls inside the stated range.
By their numbers in this assay, from the lowest: compounds 1, 2, 4 and 3 (each within the scatter of the next, the first and the last beyond it).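

In this assay, replacing the 2-hydroxyphenyl with the larger 2-(4-methoxyphenyl)ethenyl, which brings a double bond outside the rings and has no hydrogen-bond donor, gives a difference within the scatter (a 1.7-fold lower number from compound 3 to compound 4 (0.22 log units; within the scatter)), and replacing the 2-methoxyphenyl gives the same kind of result (a 1.3-fold higher number from compound 2 to compound 4 (0.13 log units; within the scatter)); this place on the shared core, para to a large group, therefore accepts the longer arm with no change that can be told from the scatter. Only against the 2-chlorophenyl of compound 1 does the arm give a real difference (a 2.6-fold higher number from compound 1 to compound 4 (0.41 log units; beyond the scatter)), so across these compounds the extension brings no gain over the chloro ring. Nothing shown here accounts for these numbers.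

The arm differs from the smaller rings in its length, its double bond and the place of its methoxy all at once, so the share of each in the result stays unresolved. Also open, as far as these compounds go, is how an ethenyl arm carrying a chloro group, an amine or a carboxylic acid in place of the methoxy would read in this assay and whether any of these would improve on compound 1.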